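The compounds below may be only part of what the source reports. "The series", "measured", "known", "first", "only" and "open" are said of these compounds alone.

Measured so far in a functional assay on the whole organism (blood, strain Wistar-Okamoto) with Rattus norvegicus as the target, with a stated time of 5 days; a lower number here means that less compound is needed, a higher number that more compound is needed for the effect:
compound 1, `N#CNC(=N)Nc1cccnc1`, gives 50 mg/kg
compound 2, `CCCC/N=C(\NC#N)Nc1cccnc1`, gives 20 mg/kg
compound 3, `CCCCC(CC)C/N=C(\NC#N)Nc1cccnc1`, gives > 50 mg/kg, which is a limit of the assay and not a number

Compound 2 stands lowest of the two numbers in this assay; the nearest number is that of compound 1, and the gap between them is beyond the scatter. Compound 3 sits at the limit of > 50 mg/kg in this assay, at which 1 of the 3 values shown sits.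

Compound 4, `CCC(CC)/N=C(\NC#N)Nc1cccnc1`, differs from compound 2 in one place: pentan-3-yl in place of butyl on a double-bonded nitrogen. For the measured compounds named here, the one measured step that bears on this change is an at least 2.5-fold higher number from compound 2 to compound 3 (0.39 log units; beyond the scatter), where adding carbon to the chain on the double-bonded nitrogen made a larger, branched group and ended in a limit. Going by the values given here, the change to compound 4 also branches the chain at the carbon that stands on the double-bonded nitrogen, but the group that enters is smaller than the one in compound 3 and adds only one heavy atom to butyl. A step in the same direction, weaker than the measured one, is therefore expected, and the expected size is a 1.5-fold higher number from compound 2 to compound 4 (0.18 log units; within the scatter). Compound 4 is expected to give about 30 mg/kg in this assay, with a range from 15 mg/kg to 60 mg/kg, and with some chance that only a limit is reported.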

Compound 4, minimum effective dose: 20 mg/kg
Compound 4: middle estimate off by 1.5-fold (0.18 log units), on the high side; measured number inside the range.
By their numbers in this assay, from the lowest: compounds 2 and 4 (each within the scatter of the next); then compound 1.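

In this assay, pentan-3-yl in place of butyl on a double-bonded nitrogen reads as no change at the digits printed from compound 2 to compound 4 (within the scatter), so this position takes a chain branched at the carbon on that nitrogen with no step beyond the scatter. Branching of this size therefore does not by itself move the number in this assay, and the single step from butyl seen earlier, an at least 2.5-fold higher number from compound 2 to compound 3 (0.39 log units; beyond the scatter), cannot be read as a general penalty for every branched group at this place. Compound 3 remains the only compound in the series with a limit, which is a limit of the assay and not a number: the limit of > 50 mg/kg in this assay, at which 1 of the 4 values shown sits.

The compounds shown leave open where between pentan-3-yl and the larger group of compound 3 the number in this assay begins to rise, and whether a longer unbranched chain such as octyl behaves like butyl or like that larger group. They also leave open whether a ring such as cyclohexyl, or a butyl chain ending in an amine or a carboxylic acid, on the double-bonded nitrogen would hold the number shared by compound 2 and compound 4.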